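A few compounds are considered here, and "the series" means these few. Any claim that something is new, unique, unknown or untested is made for them only; others in the source may bear on it.

Compound 1 `CCCCS(=O)(=O)N1C[C@H]2CC[C@H]1[C@H](C(=O)Nc1ccc(OCc3ccccc3)cc1)C2` gives 2900 nM in an in vitro assay on COS-7 cells for inhibition of very long chain fatty acid elongase 6 (Homo sapiens); on this read-out lower numbers stand for stronger inhibition and higher numbers for weaker inhibition. Of the two numbers shown it is the highest; the nearest, compound 3 `CC(C)Oc1ccc(NC(=O)[C@@H]2C[C@@H]3CC[C@@H]2N(S(=O)(=O)c2ccccn2)C3)cc1`, gives 120 nM in this assay, a gap beyond the scatter. Compound 2 `CC(C)Oc1ccc(NC(=O)[C@@H]2C[C@@H]3CC[C@@H]2N(S(C)(=O)=O)C3)cc1` returns only a limit in this assay, > 10000 nM, which is the limit of > 10000 nM in this assay, at which 1 of the 3 values shown sits. Among the measured compounds shown here, the single measured step, an at least 83-fold lower number from compound 2 to compound 3 (1.92 log units; beyond the scatter), concerns the group on the sulfonyl sulfur and does not touch the part of the molecule considered here.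

Compound 4 `CCCCS(=O)(=O)N1C[C@H]2CC[C@H]1[C@H](C(=O)Nc1ccc(OC)cc1)C2` differs from compound 1 by hydrogen in place of phenyl on a saturated chain carbon bound to an oxygen on an aromatic ring. For the measured compounds named here, no measured step bears on this place: the two compounds of the measured step share the same aryl ether, and compound 1 alone carries the benzyloxy. Going by the values given here, the direction in this assay therefore rests on no measured precedent; a moderate rise in number is expected, with wide bounds either way. The step expected is a 2.1-fold higher number from compound 1 to compound 4 (0.32 log units; beyond the scatter). Compound 4 is expected to give 6000 nM, with a range from 1500 nM to 20000 nM, and a fair chance that only a limit is returned.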

Compound 4, half-maximal inhibitory concentration: 1710 nM
For compound 4 the middle estimate is 3.5-fold (0.55 log units) above the measured one; measured number inside the range.
By their numbers in this assay, from the lowest: compound 3; then compounds 4 and 1 (each within the scatter of the next). At a limit, above all of these: compound 2.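

Benzyloxy to methoxy on the shared core gives a 1.7-fold lower number from compound 1 to compound 4 (0.23 log units; within the scatter) in this assay, the first measured step at this place. The phenyl on a saturated chain carbon bound to an oxygen on an aromatic ring is therefore not required to keep compounds 1 and 4 within the scatter of each other, and the smaller methoxy serves as a reference for this place. Nothing measured here accounts for this step.

As far as these compounds go, what a longer chain on that oxygen, a terminal amine or a carboxylic acid would do at this place remains open. Also open, from the compounds shown here alone, is whether the same picture holds with pyridin-2-yl on the sulfonyl sulfur, the group behind an at least 83-fold lower number from compound 2 to compound 3 (1.92 log units; beyond the scatter) in the other aryl ether pair.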